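From phenoxy to 4-fluorophenoxy in compound 3

The source may hold more compounds than are shown below. What is called first, only, known or untested is meant among the compounds shown, and "the series" means these compounds.

- compound 1 `COc1cc(/C=C/c2ccc(C3=C(c4ccc(O)cc4)C4CC(S(=O)(=O)Oc5ccccc5)C3O4)cc2)cc(OC)c1` gives > 100000 nM as a limit
- compound 2 `O=S(=O)(Oc1ccccc1)C1CC2OC1C(c1ccc(/C=C/c3cc(O)cc(O)c3)cc1)=C2c1ccc(O)cc1` gives 20100 nM as a number

For the measured compounds named here, in a functional assay on MCF7 cells (Homo sapiens) for antiproliferative activity, read by MTT assay, with a stated time of 72 h (a higher number here means a weaker inhibitor, a lower number a stronger inhibitor), compound 2 gives 20100 nM as the only true number so far. Compound 1 stands at > 100000 nM and that value is a limit of the assay.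

Compound 3 `O=S(=O)(Oc1ccc(F)cc1)C1CC2OC1C(c1ccc(/C=C/c3cc(O)cc(O)c3)cc1)=C2c1ccc(O)cc1` differs from compound 2 by fluoro in place of hydrogen on an aromatic carbon with fluoro in place of hydrogen on an aromatic carbon, turning phenoxysulfonyl into (4-fluorophenoxy)sulfonyl. Going by the values given here, the sole measured step is an at least 4.9-fold lower number from compound 1 to compound 2 (0.69 log units; beyond the scatter) and it concerns 3,5-dihydroxyphenyl in place of 3,5-dimethoxyphenyl, not the phenoxy group, so it gives no size for this change. No shift beyond the scatter is therefore expected in this assay and compound 2 remains the anchor. The expected step is a 1.0-fold lower number from compound 2 to compound 3 (0.00 log units; within the scatter) and it is estimated to stay within the scatter. Compound 3 is estimated at 20000 nM with an expected range from 8000 nM to 50000 nM for now.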

Compound 3, half-maximal inhibitory concentration: 13100 nM
Estimate against measurement, compound 3: 1.5-fold (0.18 log units) above; low and high end bracket the measured number.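

In this assay, the phenoxy group on the sulfonyl now has a reading of its own, whereas the earlier step concerned only the 3,5-dihydroxyphenyl end of the molecule. Fluoro in place of hydrogen, on an aromatic carbon para to a large group, gives a 1.5-fold lower number from compound 2 to compound 3 (0.19 log units; within the scatter), so this position accepts a single fluoro with no change that can be told from the scatter. No measurement shown accounts for the size of this step.

From the compounds shown here alone, only hydrogen and fluoro have been read at this position, so a chloro, a methoxy, an amine or a carboxylic acid in the same place remains open. Also open, going by these compounds, is whether the 4-fluorophenoxy group would read the same alongside 3,5-dimethoxyphenyl instead of 3,5-dihydroxyphenyl.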